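Swapping the group on the oxygen: compound 3 to compound 4

The source may report more compounds than this note shows. Statements on the series, on what has been measured and on what is new or still open speak of the compounds shown alone.

In a functional assay (blood) for inhibition, with Homo sapiens as the target (on this read-out lower numbers stand for stronger inhibition and higher numbers for weaker inhibition), compound 3 `C/C(=N\OCc1ccncc1)c1ccc(Sc2cc(F)cc(C3CCOCC3)c2)cc1` gives 300 nM, the highest of the three numbers measured here. Compound 1 `C/C(=N\OCCSc1nnc(C)s1)c1ccc(Sc2cc(F)cc(C3CCOCC3)c2)cc1` gives 230 nM, and the step of a 1.3-fold higher number from compound 1 to compound 3 (0.12 log units; within the scatter) lies within the scatter. Compound 2 `CO[C@]1(c2cc(F)cc(S(=O)(=O)c3ccc(/C(C)=N/O)cc3)c2)CCO[C@@H](C)C1` gives 20 nM, a number that stands beyond the scatter from compound 3. Compound 4 `C/C(=N\OC(=O)C(C)(C)C)c1ccc(Sc2cc(F)cc(C3CCOCC3)c2)cc1` differs from compound 3 as follows: (tert-butyl)carbonyl in place of (pyridin-4-yl)methyl on an oxygen. Among the compounds with values here, the only measured step that bears on this change is the one at the same oxygen, a 1.3-fold higher number from compound 1 to compound 3 (0.12 log units; within the scatter), which stayed within the scatter, so in this assay no step beyond the scatter is expected in either direction. Compound 4 is therefore estimated at 300 nM, between 100 nM and 900 nM, an expected step of no change at the digits printed from compound 3 to compound 4 (within the scatter).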

Compound 4, half-maximal inhibitory concentration: 40 nM
The estimate for compound 4 lay 7.5-fold (0.88 log units) above the measured number; the whole stated range lies above it.
By their numbers in this assay, from the lowest: compounds 2 and 4 (each within the scatter of the next); then compounds 1 and 3 (each within the scatter of the next).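

In this assay the oxygen bound to the double-bonded nitrogen proves sensitive to what it carries: (tert-butyl)carbonyl gives a step beyond the scatter against (pyridin-4-yl)methyl (a 7.5-fold lower number from compound 3 to compound 4 (0.88 log units; beyond the scatter)) and against 2-((5-methyl-1,3,4-thiadiazol-2-yl)sulfanyl)ethyl (a 5.8-fold lower number from compound 1 to compound 4 (0.76 log units; beyond the scatter)). The two ring-bearing groups had stayed within the scatter of each other, so only the group with no ring and a carbonyl separates from them. Nothing measured here accounts for this step.

The compounds shown do not tell whether the carbonyl or the tert-butyl carries the step. An acetyl group or a 2,2-dimethylpropyl chain on the same oxygen would separate the two.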